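A few compounds are considered here, and "the series" means these few. Any claim that something is new, unique, unknown or untested is made for them only; others in the source may bear on it.

Measured so far:
Compound 1 `CCCC(=O)N1N=C(c2cc(OC)ccc2N)SC1(C)C` gives 91.1% in an assay on isolated protein for inhibition of Nitric oxide synthase, inducible (Homo sapiens), read by scintillation counting, with a stated time of 30 min, tested at 50 uM; a lower number here means less inhibition, a higher number more inhibition at the concentration tested (going by the name of the read-out).
Compound 2 `COc1ccc(N)c(C2=NN(C(=O)C3CCCC3)C(C)(C)S2)c1` gives 65%.
Compound 3 `CCCC(=O)N1N=C(c2cc(Cl)ccc2N)SC1(C)C` gives 66.2%.

Among these three, compound 3 stands second highest; its value and that of compound 2 lie within the scatter of each other, while compound 1 sits higher by a number 24.9 percentage points lower from compound 1 to compound 3 (beyond the scatter). Compound 4 `CC1(C)SC(c2cc(Cl)ccc2N)=NN1C(=O)c1ccccc1` differs from compound 3 by phenyl in place of propyl on a carbonyl carbon. For the measured compounds named here, the one measured step at the same place is a number 26.1 percentage points lower from compound 1 to compound 2 (beyond the scatter), a modest loss when the propyl chain was replaced by a ring. Phenyl is a different ring, so the direction is not certain, but a similar modest loss seems the most reasonable expectation. Compound 4 is therefore estimated at 50%, with a likely range of 25% to 75%, which would be an expected step of a number 16.2 percentage points lower from compound 3 to compound 4 (beyond the scatter).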

Compound 4, a percentage reported as inhibition, at one concentration (the size of the read-out at that concentration, not a potency): 20.8%
For compound 4 the middle estimate is 29.2 percentage points above the measured one; the whole stated range lies above it.
By their numbers in this assay, from the lowest: compound 4; then compounds 2 and 3 (each within the scatter of the next); then compound 1.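

Putting phenyl in place of propyl on this carbonyl carbon gives a number 45.4 percentage points lower from compound 3 to compound 4 (beyond the scatter), a large loss that shows this position can strongly change the inhibition read-out. Together with a number 26.1 percentage points lower from compound 1 to compound 2 (beyond the scatter), this gives two cases in which a ring in place of propyl lowers the number, although those two pairs carry different groups elsewhere on the core. Nothing measured here explains the size of the new loss.

Going by these compounds, whether an ethyl group or a longer pentyl chain at this carbonyl carbon would preserve inhibition remains open. So does the effect of phenyl with methoxy in place of chloro.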